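Changing the Aryl Group: Ethyl Replaced by Nitro

The source may hold more compounds than are shown below. What is called first, only, known or untested is meant among the compounds shown, and "the series" means these compounds.

Compound 1, `CC(C)(C)n1ncc(OCc2nnc(-c3ccccc3Cl)o2)c(Cl)c1=O`: 61200 nM
Compound 2, `Cc1cc(C)cc(-c2nnc(COc3cnn(C(C)(C)C)c(=O)c3Cl)o2)c1`: > 299000 nM (a limit)
Compound 3, `CCc1ccc(-c2nnc(COc3cnn(C(C)(C)C)c(=O)c3Cl)o2)cc1`: 14500 nM

In a functional assay on the whole organism for inhibition, with Mythimna separata as the target, with a stated time of 5 days (a higher number here means that more compound is needed for the effect, a lower number that less compound is needed), compound 3 gives the lowest of the two numbers shown; compound 1 is its nearest neighbour, and the step of a 4.2-fold lower number from compound 1 to compound 3 (0.63 log units; beyond the scatter) lies beyond the scatter. Compound 2 reaches only a limit of this assay, (the limit of > 299000 nM in this assay, at which 1 of the 3 values shown sits). Compound 4, `CC(C)(C)n1ncc(OCc2nnc(-c3ccc([N+](=O)[O-])cc3)o2)c(Cl)c1=O`, differs from compound 3 by nitro in place of ethyl on an aromatic carbon. Going by the values given here, no measured step exchanges a group on that same aromatic carbon; the nearest are a 4.2-fold lower number from compound 1 to compound 3 (0.63 log units; beyond the scatter) and an at least 20-fold lower number from compound 2 to compound 3 (1.31 log units; beyond the scatter), which show that the aryl group moves the number by modest to large amounts. A step beyond the scatter is therefore plausible, its direction uncertain. Compound 4 is estimated at 30000 nM, between 8000 nM and 150000 nM. That estimate is expected to mean a 2.1-fold higher number from compound 3 to compound 4 (0.32 log units; beyond the scatter).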

Compound 4, half-maximal effective concentration: > 299000 nM
Compound 4 gave a limit, no number (the forecaster's own chance of this, stated with the estimate: 15%); middle value at least 9.9-fold (0.99 log units) away from the limit.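

In this assay, exchanging only the group on the aromatic carbon of the 4-ethylphenyl ring gives a large step: an at least 20-fold higher number from compound 3 to compound 4 (1.31 log units; beyond the scatter). The 4-nitrophenyl group therefore does not keep the advantage that 4-ethylphenyl holds over 2-chlorophenyl, and it falls on the other side of compound 1, with an at least 4.8-fold higher number from compound 1 to compound 4 (0.68 log units; beyond the scatter). Compound 4 gives a limit, not a number, and shares it with compound 2, so the step between those two cannot be read: the limit of > 299000 nM in this assay, at which 2 of the 4 values shown sit.

From the compounds shown here alone, whether a longer chain, a methoxy group or an amine on that carbon would keep the lower number of compound 3 remains open.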